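From 5-Methylpyridin-2-yl to 5-Chloropyridin-2-yl

A few compounds are considered here, and "the series" means these few. Any claim that something is new, unique, unknown or untested is made for them only; others in the source may bear on it.

In an ADME assay on a cell-free system (plasma, Homo sapiens) for protein binding, compound 1 (`Cc1ccc([C@@H](C)Oc2cc3oc(=O)n(CCC(=O)O)c3cc2Cl)nc1`) gives 97.8%. Going by the values given here, compound 2 (`O=C(O)CCn1c(=O)oc2cc(OCC3CCC3)c(Cl)cc21`), the only other compound measured, gives 98.1%. The two values lie within the scatter of each other, so compound 1 stands level with compound 2.

Compound 3 (`C[C@@H](Oc1cc2oc(=O)n(CCC(=O)O)c2cc1Cl)c1ccc(Cl)cn1`) has not yet been measured. It departs from compound 1 in one place, where 5-methylpyridin-2-yl becomes 5-chloropyridin-2-yl: chloro in place of methyl on an aromatic carbon. This puts chloro in place of methyl on an aromatic carbon, para to a large group.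

Among the compounds with values here, no measured pair shows this exchange directly. Within the data shown here, the only guide is how close compound 2 at 98.1% comes to compound 1 at 97.8%, though the two carry different groups on the shared core. The expected change is a 1.1-fold lower unbound fraction from compound 1 to compound 3 (0.04 log units; within the scatter), none beyond the scatter. For compound 3 the estimated value is 98%, with an expected range of 96.5% to 99.1%.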

Compound 3, plasma protein binding: 99%
Compound 3: the middle estimate sits 2.0-fold (0.30 log units) (unbound fraction) above what was measured; the measured number falls inside the stated range.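

In this assay, the change from 5-methylpyridin-2-yl to 5-chloropyridin-2-yl gives a 2.2-fold lower unbound fraction from compound 1 to compound 3 (0.34 log units; beyond the scatter), a modest step but the only one shown between compounds that differ in one place. It shows that this aromatic carbon, para to a large group, is a position where replacing one heavy atom with another can move the unbound fraction beyond the scatter, even though neither group carries a hydrogen-bond donor, a hydrogen-bond acceptor or a net charge. Nothing measured among these compounds accounts for the shift.

As far as these compounds go, it remains open whether fluoro, methoxy or a nitrile on the same carbon would move the unbound fraction in the same direction. Also open, from the compounds shown here alone, is whether the exchange would give a step of similar size if the carboxylic acid of the shared core gave way to an amide.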